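This account rests on a few compounds, and the source may have more. Where it says the series, first, only, none or still open, it means among the compounds named here.

Measured compounds in a functional assay for antagonist activity at melanin-concentrating hormone receptor 1 (Homo sapiens); a lower number here means a stronger inhibitor, a higher number a weaker inhibitor:
- compound 1, `N#Cc1cccc([C@]23CCC(N(CCN4CCCC(O)C4)C(=O)Nc4ccc(F)c(Cl)c4)CC2C3)c1`: compound 1 gives 22 nM
- compound 2, `CC(=O)NCc1cccc([C@]23CCC(N(CCN(C(C)C)C(C)C)C(=O)Nc4ccc(F)c(Cl)c4)CC2C3)c1`: compound 2 gives 31 nM

Of the two numbers, that of compound 2 is the higher, yet its gap to compound 1 lies within the usual scatter of this assay, so the two compounds are not separated on the evidence shown. Going by the values given here, no step between measured compounds that differ in a single place has been worked out in this pair, since compound 1 and compound 2 differ both in the aryl substituent and in the amine on the chain.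

The next compound, compound 3 `CC(C)N(CCN(C(=O)Nc1ccc(F)c(Cl)c1)C1CC[C@]2(c3cccc(CN(C)C)c3)CC2C1)C(C)C`, is reached from compound 2 by a single change: dimethylamino in place of acetamido on a saturated chain carbon bound to an aromatic carbon. The diisopropylamine chain and the urea are kept unchanged. Among the compounds with values here, with no measured step of this kind available, the expected step from compound 2 to compound 3 in this assay is a 1.2-fold lower number from compound 2 to compound 3 (0.09 log units; within the scatter), which is not expected to go beyond the scatter. Compound 3 is therefore estimated at 25 nM, with a range of 8 nM to 80 nM.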

Compound 3, inhibition constant: 13 nM
Beside the measured number, compound 3's estimate is 1.9-fold (0.28 log units) above it, and the stated range covers the measured number.
By their numbers in this assay, from the lowest: compounds 3, 1 and 2 (each within the scatter of the next, the first and the last beyond it).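

Dimethylamino in place of acetamido on a saturated chain carbon bound to an aromatic carbon gives a 2.4-fold lower number from compound 2 to compound 3 (0.38 log units; beyond the scatter) in this assay, the first change in a single place in this series, and it shows that this position can shift the number beyond the scatter while the diisopropylamine chain and the urea stay fixed. The exchange removes the carbonyl and the amide hydrogen together and also alters the group on the nitrogen, so this one step cannot tie the lower number to any one of these features. No measurement at hand bears on why the number falls, and the step stands as an observation only.

Open, on these data alone, is whether a basic-type replacement is needed at all: a primary amine, a pyrrolidine or a methoxy group on the same chain carbon, or a longer chain between the aromatic ring and the nitrogen, would each test a separate part of the exchange. Also open, as far as these compounds go, is whether the same exchange gives a step of similar size with the amine on the chain of compound 1.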